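Phenyl for cyclohexyl on a second quinazolinone core

A few compounds are considered here, and "the series" means these few. Any claim that something is new, unique, unknown or untested is made for them only; others in the source may bear on it.

Measured compounds:
compound 1 `C[C@H](Nc1nc(O)c2cc(Cl)ccc2n1)C1CCCCC1`, 15100 nM;
compound 2 `C[C@H](Nc1nc(O)c2cc(Cl)ccc2n1)c1ccccc1`, 13200 nM;
compound 3 `Oc1nc(NCC2CCCCC2)nc2ccc(I)cc12`, 26000 nM.

The three measured compounds were tested in a functional assay (ileum) for inhibition, with Cavia porcellus as the target; on this read-out higher numbers stand for weaker inhibition and lower numbers for stronger inhibition. Compound 1 and compound 2 share one core and differ only by phenyl in place of cyclohexyl on a saturated chain carbon bound to a nitrogen on an aromatic ring and a saturated chain carbon. That exchange gave a 1.1-fold lower number from compound 1 to compound 2 (0.06 log units; within the scatter). Compound 3 sits on a different core; the difference between the two cores is not broken down here, and the value of compound 3 lies close to those of compound 1 and compound 2.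

Compound 4 `Oc1nc(NCc2ccccc2)nc2ccc(I)cc12` is not yet measured. Going by the values given here, it differs from compound 3 by phenyl in place of cyclohexyl on a saturated chain carbon bound to a nitrogen on an aromatic ring, the same kind of change as the one from compound 1 to compound 2, though the place differs: in compound 1 the carbon carrying the ring is bound to a nitrogen on an aromatic ring and a saturated chain carbon, whereas in compound 3 it is bound to a nitrogen on an aromatic ring only. Because the earlier exchange gave a 1.1-fold lower number from compound 1 to compound 2 (0.06 log units; within the scatter), compound 4 is expected to show a 1.1-fold lower number from compound 3 to compound 4 (0.05 log units; within the scatter). Compound 4 is therefore estimated at 23000 nM, with a range from 8000 nM to 60000 nM.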

Compound 4, half-maximal inhibitory concentration: 8700 nM
Beside the measured number, compound 4's estimate is 2.6-fold (0.42 log units) above it, and the stated range covers the measured number.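

In this assay, phenyl in place of cyclohexyl on a saturated chain carbon bound to a nitrogen on an aromatic ring gave a 3.0-fold lower number from compound 3 to compound 4 (0.48 log units; beyond the scatter), a modest gain in inhibition on the core of compound 3. Set beside the same exchange on the core of compound 1, the two results cannot be told apart: the same change on two cores in this assay, a 1.1-fold lower number (0.06 log units; within the scatter) from compound 1 to compound 2 and a 3.0-fold lower number (0.48 log units; beyond the scatter) from compound 3 to compound 4, 2.6-fold (0.42 log units) apart, within the scatter of two such steps. Going by these compounds alone, the two pairs are therefore compatible with the change carrying over from one core to the other, but they do not show that it carries over with a fixed size, since only one of the two steps lies beyond the scatter and two pairs are a thin basis for any rule.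

The compounds shown leave open whether the exchange would behave the same way on other cores in this series. They also leave open what a longer chain between the nitrogen and the ring, or an amine or a carboxylic acid on the phenyl, would do to the read-out.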